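Carbamate in place of sulfonamide on the shared core

This account rests on a few compounds, and the source may have more. Where it says the series, first, only, none or still open, it means among the compounds named here.

Measured so far in an assay on isolated protein (Cricetulus griseus) for binding affinity to Alpha-1B adrenergic receptor (Mesocricetus auratus), read by radioligand binding; a higher number here means a weaker inhibitor, a lower number a stronger inhibitor:
compound 1 `CCCS(=O)(=O)Nc1cccc2c1CCCC2c1c[nH]cn1`: < 10000 nM
compound 2 `CS(=O)(=O)Nc1cccc2c1CCCCC2c1c[nH]cn1`: 10000 nM
compound 3 `CCS(=O)(=O)Nc1cccc(NC2=NCCN2)c1`: < 10000 nM

Compound 1 gives in this assay a limit of the assay, not a number. For compound 3 the value in this assay is likewise a limit. Compound 2 gives a number in this assay, and it sits at the same level as the two limits. Compound 1 therefore stands where two of the three results do, at the limit of < 10000 nM in this assay, at which 2 of the 3 values shown sit, so its true inhibition constant is not fixed on the numbers shown.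

Compound 4 `COC(=O)Nc1cccc2c1CCCC2c1c[nH]cn1` is the next member. The change from compound 1 is methoxycarbonyl in place of propylsulfonyl on a nitrogen on an aromatic ring. Going by the values given here, no step between measured compounds bears on this change, and nothing here connects the entering or leaving group to a shift in the inhibition constant.

In this assay compound 4 is expected to give 6000 nM, between 1500 nM and 25000 nM. The expected step that the limit leaves unreadable from compound 1 to compound 4 is put at none beyond the usual scatter, and a limit rather than a number is a fair possibility.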

Compound 4, inhibition constant: 10000 nM
Compound 4: middle estimate off by 1.7-fold (0.22 log units), on the low side; the measured number falls inside the stated range.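

Going by these compounds alone, on the nitrogen on an aromatic ring of the shared core, this assay now gives a first direct pair for this position: a number no lower from compound 1 to compound 4 (the limit leaves the size open) on exchanging propylsulfonyl for methoxycarbonyl. Within the data shown here, earlier compounds offered no pair differing in one place, so this position had no comparison until now. The size of this step cannot be read, and the pair therefore shows only the direction the values allow, not whether the change costs anything in binding.

As far as these compounds go, whether compound 1 lies close to compound 4 or far from it stays open, since the value of compound 1 is a limit and not a number. Also open, from the compounds shown here alone, is how other groups on this nitrogen would read, such as acetyl, ethoxycarbonyl or a longer carbamate chain.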